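A few compounds are considered here, and "the series" means these few. Any claim that something is new, unique, unknown or untested is made for them only; others in the source may bear on it.

Measured so far:
compound 1 `Cn1cc(-c2ccccc2F)c2cc(C(=O)NCc3ccc(C(=O)Nc4ccccc4N)cc3)[nH]c2c1=O` — 230 nM
compound 2 `Cn1cc(-c2ccccc2Oc2ccccc2)c2cc(C(=O)NCCCCCC(=O)NO)[nH]c2c1=O` — 610 nM

In a functional assay on MV4-11 cells (Homo sapiens) for antiproliferative activity, read by CCK-8 assay, with a stated time of 72 h (a lower number here means a stronger inhibitor, a higher number a weaker inhibitor), compound 1 gives the lower of the two numbers; compound 2 gives the higher one, and that gap lies beyond the scatter. Within the data shown here, no pair differing in one place has been measured, so the series itself gives no step size to lean on. Compound 3 `COc1ccccc1-c1cn(C)c(=O)c2[nH]c(C(=O)NCc3ccc(C(=O)Nc4ccccc4N)cc3)cc12` differs from compound 1 by methoxy in place of fluoro on an aromatic carbon. For this change the step expected in this assay is a 1.3-fold higher number from compound 1 to compound 3 (0.12 log units; within the scatter), small and not beyond the scatter in either direction. Compound 3 is estimated at 300 nM, within 120 nM to 750 nM.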

Compound 3, half-maximal inhibitory concentration: 200 nM
Compound 3: middle estimate off by 1.5-fold (0.18 log units), on the high side, and the stated range covers the measured number.
By their numbers in this assay, from the lowest: compounds 3 and 1 (each within the scatter of the next); then compound 2.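

In this assay the change from 2-fluorophenyl to 2-methoxyphenyl gives a 1.2-fold lower number from compound 1 to compound 3 (0.06 log units; within the scatter) and leaves the two compounds within the scatter of each other. This position, on an aromatic carbon ortho to a large group, therefore accepts methoxy in place of fluoro with no separable shift in the read-out, although the swap adds a heavy atom and a hydrogen-bond acceptor. No measurement on hand offers an explanation for this result.
Going by these compounds, whether an amine, a carboxylic acid or a longer alkoxy chain at this position would read the same remains open. So does the effect of this swap alongside the hydroxamic acid chain of compound 2.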